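The source may report more compounds than this note shows. Statements on the series, on what has been measured and on what is new or still open speak of the compounds shown alone.

Compound 3, `Cc1c(OC[C@@H](C)COc2ccc(C(=O)O)cc2Cl)ccc(C(=O)CC(C)(C)C)c1O`, gives 1650 nM in an assay for positive allosteric modulation of metabotropic glutamate receptor 3 (Rattus norvegicus) (on this read-out higher numbers stand for an effect only at larger amounts of compound and lower numbers for an effect already at smaller amounts), the highest of the three numbers in hand. Compound 1, `COc1ccc(C(=O)O)cc1OC[C@@H](C)Oc1ccc(C(=O)CC(C)(C)C)c(O)c1C`, gives 806 nM, and compound 2, `COc1cc(C(=O)O)ccc1OC[C@H](C)COc1ccc(C(=O)CC(C)(C)C)c(O)c1C`, gives 512 nM; compound 1 and compound 2 differ in more than one place, so their two values are all that can be said of them. Compound 4 is `COc1ccccc1OC[C@H](C)COc1ccc(C(=O)CC(C)(C)C)c(O)c1C`; it carries 2-methoxyphenyl in place of 4-carboxy-2-chlorophenyl on an oxygen on a saturated carbon. Going by the values given here, one measured step bears on part of this change: a 3.2-fold higher number from compound 2 to compound 3 (0.51 log units; beyond the scatter), the exchange of methoxy for chloro. Among the compounds with values here, compound 4 reverses that exchange but also drops the carboxylic acid, a change for which no measured step exists. The chloro-to-methoxy reversal suggests a return toward the number of compound 2, while the loss of the acid is unresolved, so a downward step of moderate size is expected, with wide uncertainty, for a 2.2-fold lower number from compound 3 to compound 4 (0.34 log units; beyond the scatter). Compound 4 is therefore estimated at 750 nM in this assay, in the range 250 nM to 3000 nM.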

Compound 4, half-maximal effective concentration: "not active" (no number reported)
The entry for compound 4 holds no number, so the estimate cannot be set against anything.
By their numbers in this assay, from the lowest: compounds 2 and 1 (each within the scatter of the next); then compound 3.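

In this assay compound 4 is reported as not active without a number, so no step can be read from it to compound 2 or compound 3, and no measurement here offers an explanation. The compounds shown leave open whether the missing number traces to the carboxylic acid's absence or to the methoxy group.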